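Swapping One Ring on a Side Chain

This account rests on a few compounds, and the source may have more. Where it says the series, first, only, none or still open, it means among the compounds named here.

In a functional assay on A549 cells (Homo sapiens) for antiproliferative activity, read by MTT assay, with a stated time of 48 h (on this read-out higher numbers stand for weaker inhibition and lower numbers for stronger inhibition), compound 1 `CCCn1c(N)c(-c2nc3ccccc3[nH]2)c2nc(C#N)c(C#N)nc21` gives 1970 nM and compound 2 `CN1CCN(CCCn2c(N)c(-c3nc4ccccc4[nH]3)c3nc(C#N)c(C#N)nc32)CC1` gives 5750 nM as the higher, weaker number of the two. Compound 3 `N#Cc1nc2c(-c3nc4ccccc4[nH]3)c(N)n(CCCN3CCCCC3)c2nc1C#N` keeps the shared core but carries piperidin-1-yl in place of 4-methylpiperazin-1-yl (piperidin-1-yl in place of 4-methylpiperazin-1-yl on a saturated chain carbon, three bonds along the chain from an aromatic nitrogen). Going by the values given here, the one measured step bearing on this is modest (a 2.9-fold higher number from compound 1 to compound 2 (0.47 log units; beyond the scatter)) and comes with 4-methylpiperazin-1-yl replacing hydrogen. No measurement covers the swap itself. In this assay a small expected shift towards a lower number (a 1.6-fold lower number from compound 2 to compound 3 (0.22 log units; within the scatter)) would stay within the scatter. For compound 3 the estimated value is 3500 nM within a range of 1500 nM to 8000 nM as expected.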

Compound 3, half-maximal inhibitory concentration: 6110 nM
Compound 3: middle estimate off by 1.7-fold (0.24 log units), on the low side; the measured number falls inside the stated range.
By their numbers in this assay, from the lowest: compound 1; then compounds 2 and 3 (each within the scatter of the next).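

In this assay, piperidin-1-yl in place of 4-methylpiperazin-1-yl gives a 1.1-fold higher number from compound 2 to compound 3 (0.03 log units; within the scatter) and so the two rings cannot be told apart at this chain position. Set against hydrogen, piperidin-1-yl gives a 3.1-fold higher number from compound 1 to compound 3 (0.49 log units; beyond the scatter) and so, like 4-methylpiperazin-1-yl, it stands on the weaker side of compound 1. No supporting measurement explains this result.

Still open, as far as these compounds go, is whether a smaller dimethylamino group or a morpholin-4-yl ring at this position would match these two rings or come closer to compound 1. A longer chain carrying piperidin-1-yl also remains an open question.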